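Amide-to-urea exchange on an aryl sulfonate scaffold

The compounds below may be only part of what the source reports. "The series", "measured", "known", "first", "only" and "open" are said of these compounds alone.

Measured compounds:
compound 1, `CC(C)c1ccccc1OS(=O)(=O)c1cccc(NC(=O)CCCl)c1`, 11000 nM
compound 2, `CC(C)C(=O)Nc1ccc(S(=O)(=O)Oc2ccccc2C(C)C)cc1`, 14000 nM
compound 3, `CC(C)C(=O)Nc1ccc(S(=O)(=O)Oc2ccccc2I)cc1`, 13000 nM

Of the compounds shown here, three have been tested in a functional assay on HT-29 cells (Homo sapiens) for antiproliferative activity, read by sulforhodamine B assay, with a stated time of 48 h; a lower number here means a stronger inhibitor, a higher number a weaker inhibitor. Compound 2 carries the highest of the three numbers, but it is within the scatter of both neighbours: compound 3 lies nearest, with a 1.1-fold lower number from compound 2 to compound 3 (0.03 log units; within the scatter), and compound 1 lies furthest, yet still within the scatter. The three values therefore describe a single narrow band of weak inhibition.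

Compound 4, `CCCCCNC(=O)Nc1ccc(S(=O)(=O)Oc2ccccc2C(C)C)cc1`, has not yet been measured. It differs from compound 2 in one place: pentylamino in place of isopropyl on a carbonyl carbon. The isopropylcarbonyl group becomes a pentylcarbamoyl group, so the (isopropylcarbonyl)amino unit of compound 2 is read as a (pentylcarbamoyl)amino unit in compound 4.

For the measured compounds named here, none of the measured steps touches this position. Going by the values given here, the only step on record, from compound 2 to compound 3, alters a substituent on the aromatic ring and stays within the scatter. The data thus give no guidance for a change at the carbonyl carbon, and the expectation for compound 4 in this assay rests on the flat band alone.

Compound 4 is therefore expected to give 12000 nM, within a range from 4000 nM to 40000 nM, which corresponds to an estimated 1.2-fold lower number from compound 2 to compound 4 (0.07 log units; within the scatter).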

Compound 4, half-maximal inhibitory concentration: 4900 nM
Compound 4: the middle estimate sits 2.4-fold (0.39 log units) above what was measured; measured number inside the range.
By their numbers in this assay, from the lowest: compound 4; then compounds 1, 3 and 2 (each within the scatter of the next).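

In this assay, pentylamino in place of isopropyl on the carbonyl carbon gives a 2.9-fold lower number from compound 2 to compound 4 (0.46 log units; beyond the scatter), and this modest step is the only one shown that lies beyond the scatter. The earlier step, a change on the aromatic ring, gave a 1.1-fold lower number from compound 2 to compound 3 (0.03 log units; within the scatter), so the carbonyl carbon is the one position here at which a replacement clearly moves the number. The exchange turns the amide of compound 2 into the urea of compound 4 and also lengthens the chain, so this single step cannot separate the urea nitrogen from the pentyl chain. Nothing available here explains the shift.

The compounds shown leave open whether the urea nitrogen or the chain carries the step: methylamino or cyclohexylamino on the same carbonyl carbon, or a plain pentyl group there without the nitrogen, would pull the two apart. They also leave open whether pentylamino on the carbonyl carbon of compound 3, with its iodo group, would give a step of similar size.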